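Plasma stability across a linked diaryl ether acid series

This account rests on a few compounds, and the source may have more. Where it says the series, first, only, none or still open, it means among the compounds named here.

compound 1 `CCC(=O)c1ccc(OCCCCOc2ccc(F)c(C(=O)O)c2)c(C)c1O`: 96%
compound 2 `COc1ccc(C(=O)O)cc1OCCCCOc1ccc(C(=O)CC(C)C)c(O)c1C`: 99%
compound 3 `Cc1c(OCCCCOc2ccc(C(=O)O)cc2F)ccc(C(=O)CC2CCCC2)c1O`: 97%

Of the compounds shown here, three have so far been read in an ADME assay on a cell-free system (plasma, Rattus norvegicus) for metabolic stability, read by LC-MS, with a stated time of 60 min, tested at 100 uM; a lower number here means that less of the compound is left, a higher number that more of the compound is left. In this assay compound 1 gives 96%, compound 2 gives 99% and compound 3 gives 97%. Compound 1 holds the lowest of the three readings, yet its gaps to compound 3 and to compound 2 both lie within the usual scatter of such measurements, so the three compounds read alike: nearly all of each remains after the stated time. Within the data shown here, no pair among them differs in a single place, so no measured step can be drawn on.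

Compound 4 `Cc1c(OCCCCOc2ccc(F)c(C(=O)O)c2)ccc(C(=O)C(C)C)c1O` has not yet been measured. It differs from compound 1 by methyl in place of hydrogen on a saturated chain carbon bound to a carbonyl carbon and a saturated chain carbon. With every measured compound holding at the top of the scale and no step of this kind in the set, the step from compound 1 to compound 4 is expected to be no change at the digits printed from compound 1 to compound 4 (within the scatter), that is, nothing beyond the scatter. Compound 4 is estimated to give 96%, in a range from 88% to 100%.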

Compound 4, percent of the compound remaining: 83%
For compound 4 the middle estimate is 13 percentage points above the measured one, outside the stated range (below it).
By their numbers in this assay, from the lowest: compound 4; then compounds 1, 3 and 2 (each within the scatter of the next).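

In this assay, this place on the chain proves sensitive: methyl in place of hydrogen on a saturated chain carbon bound to a carbonyl carbon and a saturated chain carbon, which turns propanoyl into isopropylcarbonyl, gives a number 13 percentage points lower from compound 1 to compound 4 (beyond the scatter). Among these compounds, a single added methyl is therefore enough to move the reading beyond the scatter, something the earlier compounds could not show, as no two of them differ in only one place. Nothing available accounts for this step.

On these data alone, the step is seen only once, so whether it would hold on a different core remains open. The compounds shown also leave open what a tert-butyl or cyclopropyl group, or a longer chain, would do at this place.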